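A few compounds are considered here, and "the series" means these few. Any claim that something is new, unique, unknown or untested is made for them only; others in the source may bear on it.

Compound 1 `CC(=O)c1ccc(NC(=O)CN(C(=O)c2ccccc2)S(=O)(=O)c2ccc(C)cc2)cc1` stands at the bottom of the small set so far. In a functional assay for inhibition, read by spectrophotometry, with a stated time of 20 min, tested at 5 mg/mL (on this read-out higher numbers stand for a stronger effect at the one concentration tested and lower numbers for a weaker effect), compound 1 gives 18.7%, the lowest of the three numbers. Its nearest neighbour is compound 3 `CC(=O)c1ccc(NC(=O)C(C(C)C)N(C(=O)c2ccccc2)S(=O)(=O)c2ccc(C)cc2)cc1`, which in this assay gives 42.7%, and the furthest is compound 2 `CC(=O)c1ccc(NC(=O)C(CC(C)C)N(C(=O)c2ccccc2)S(=O)(=O)c2ccc(C)cc2)cc1`, which in this assay gives 71.3%. All three measured steps concern one position, the saturated chain carbon bound to an amide-type nitrogen and a carbonyl carbon: a number 52.6 percentage points higher from compound 1 to compound 2 (beyond the scatter), a number 24 percentage points higher from compound 1 to compound 3 (beyond the scatter) and a number 28.6 percentage points lower from compound 2 to compound 3 (beyond the scatter).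

Compound 4 `CC(=O)c1ccc(NC(=O)CN(C(=O)c2ccccc2)S(=O)(=O)c2ccc([N+](=O)[O-])cc2)cc1` differs from compound 1 elsewhere: nitro in place of methyl on an aromatic carbon. The change sits on an aromatic carbon of a six-membered aromatic ring of carbon only, para to a large group, while the saturated chain carbon keeps its hydrogen as in compound 1. Among the measured compounds shown here, none of the measured steps touches that ring, so none of them bears on this change, and there is no measured step of any size to lean on. With the chain carbon unchanged, the expectation for compound 4 is a step no larger than the scatter, in either direction, a number 1.3 percentage points higher from compound 1 to compound 4 (within the scatter). Compound 4 is therefore estimated at 20%, with a range from 5% to 45%.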

Compound 4, a percentage reported as inhibition, at one concentration (the size of the read-out at that concentration, not a potency): 20.7%
Compound 4: the middle estimate sits 0.7 percentage points below what was measured; measured number inside the range.
By their numbers in this assay, from the lowest: compounds 1 and 4 (each within the scatter of the next); then compound 3; then compound 2.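

Nitro in place of methyl, the 4-methylphenyl to 4-nitrophenyl exchange, is the first change shown away from the saturated chain carbon, and in this assay it gives a number 2 percentage points higher from compound 1 to compound 4 (within the scatter) so that compound 1 and compound 4 cannot be told apart on this read-out. The steps at the chain carbon, such as a number 52.6 percentage points higher from compound 1 to compound 2 (beyond the scatter) and a number 24 percentage points higher from compound 1 to compound 3 (beyond the scatter) all lie beyond the scatter, whereas this single pair shows that, with the chain carbon keeping its hydrogen, an aromatic carbon para to a large group can carry either methyl or nitro without a step beyond the scatter. No measurement among the data shown accounts for this result or says how either group acts at this place.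

What remains open is whether the same exchange would read alike on the isobutyl-bearing compound 2 or the isopropyl-bearing compound 3, since the one pair shown has only hydrogen on the chain carbon. Going by these compounds, it also remains open how this aromatic carbon would read with an amine, a carboxylic acid or a methoxy group in place of methyl or nitro.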